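Cytotoxicity notes: indolyl swap at the aromatic carbon

The compounds below may be only part of what the source reports. "The series", "measured", "known", "first", "only" and "open" are said of these compounds alone.

Compound 1 `CCOC(=O)CCCCCOc1cccc(CN(C(=O)c2ccc(-c3cccc(-c4ccccc4)c3)cc2)C(C)C)c1`, compound 2 `CCOC(=O)CCCCCOc1cccc(CN(C(=O)c2ccc(-c3ccc4[nH]ccc4c3)cc2)C(C)C)c1` and compound 3 `CCOC(=O)CCCCCOc1cccc(CN(C(=O)c2ccc(-c3ccc4c(c3)OCCO4)cc2)C(C)C)c1` share one core and differ only in the group attached to an aromatic carbon. In an ADME assay on BJ cells (Homo sapiens) for cytotoxicity, read by CellTiter-Glo and resazurin assay, with a stated time of 72 h (a higher number here means that more compound is needed for the effect, a lower number that less compound is needed), compound 1 reaches only a limit, > 26000 nM. In this assay compound 2 likewise gives a limit, > 26000 nM. Compound 3 also stops at a limit, > 24400 nM. The three steps, a step that the two limits leave unreadable from compound 1 to compound 2, a step that the two limits leave unreadable from compound 1 to compound 3 and a step that the two limits leave unreadable from compound 2 to compound 3, are unreadable because every value sits at the limit of > 26000 nM in this assay, at which 2 of the 3 values shown sit, or (the limit of > 24400 nM in this assay, at which 1 of the 3 values shown sits); compound 3 therefore stands level with the other two as far as the numbers go, with nothing read beyond a limit.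

Compound 4 `CCOC(=O)CCCCCOc1cccc(CN(C(=O)c2ccc(-c3ccc4cc[nH]c4c3)cc2)C(C)C)c1` is not yet measured. The change is 1H-indol-6-yl in place of 2,3-dihydro-1,4-benzodioxin-6-yl on an aromatic carbon. All measured steps bear on it in form, each an aryl swap at the same carbon, yet none yields a size. Compound 4 is expected to behave like compound 3, with a step that the limit leaves unreadable from compound 3 to compound 4 in this assay, meaning no readable change. Compound 4 is estimated at 30000 nM, within 15000 nM to 100000 nM, most likely reported again as a limit.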

Compound 4, half-maximal effective concentration: > 26000 nM
Compound 4: a limit, no number; the forecaster's own chance of this, stated with the estimate: 85%; the middle value is on the limit's open side.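

In this assay compound 4 gives only a limit, > 26000 nM. Within the data shown here, no step between compound 4 and compound 1, compound 2 or compound 3 can be read. The compounds shown leave open whether any aryl group at this carbon gives a measurable half-maximal effect in this assay.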